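Piperidine Swapped for Cyclopropylphenyl: Expected Microsomal Clearance

The compounds below may be only part of what the source reports. "The series", "measured", "known", "first", "only" and "open" are said of these compounds alone.

Compound 1 `COc1cccc(NC(=O)c2nnn(CC3CCNCC3)c2N)c1` was tested in an ADME assay on microsomes from liver (Mus musculus, strain CD1) for metabolic stability, read by HPLC, using NADPH, with a stated time of 30 min; on this read-out higher numbers stand for fast clearance and lower numbers for slow clearance. In this assay compound 1 gives < 0.5 mL.min-1.g-1, which is a limit of the assay rather than a measured number (the limit of < 0.5 mL.min-1.g-1 in this assay, at which 1 of the 2 values shown sits). Compound 2 `COc1cccc(NC(=O)c2nnn(Cc3ccccc3)c2N)c1` gives 3.7 mL.min-1.g-1 in this assay. Among the compounds with values here, the single measured step, an at least 7.4-fold higher number from compound 1 to compound 2 (0.86 log units; beyond the scatter), is the only comparison available, and it cannot be pinned down more closely since compound 1 sits at a limit.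

Compound 3 `COc1cccc(NC(=O)c2nnn(Cc3ccc(C4CC4)cc3)c2N)c1` differs from compound 1 by 4-cyclopropylphenyl in place of piperidin-4-yl on a saturated chain carbon bound to an aromatic nitrogen. Within the data shown here, the entering group contains the same phenyl that enters compound 2, with a cyclopropyl added, so a step at least as large as the one to compound 2 is expected, in the direction of faster clearance. Compound 3 is therefore expected to give about 5 mL.min-1.g-1 in this assay, within a range of 2 mL.min-1.g-1 to 12 mL.min-1.g-1. That estimate corresponds to an expected step of an at least 10-fold higher number from compound 1 to compound 3 (1.00 log units; beyond the scatter).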

Compound 3, intrinsic clearance in microsomes in the Mus musculus assay: 4.9 mL.min-1.g-1
Beside the measured number, compound 3's estimate is 1.0-fold (0.01 log units) above it, and the stated range covers the measured number.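

In the Mus musculus assay, the full change gives an at least 9.8-fold higher number from compound 1 to compound 3 (0.99 log units; beyond the scatter), while the cyclopropyl alone gives a 1.3-fold higher number from compound 2 to compound 3 (0.12 log units; within the scatter), so among these compounds the phenyl already accounts for the move away from compound 1, and the added cyclopropyl makes no difference that can be told from the scatter. In a physicochemical assay for solubility, read by nephelometry, at pH 7.4 (on this read-out lower numbers stand for lower solubility and higher numbers for higher solubility), compound 1 gives > 250000 nM, which is a limit of the assay and not a number. In the physicochemical assay compound 3 gives 79000 nM, which makes an at least 3.1-fold lower number from compound 1 to compound 3 (0.50 log units; beyond the scatter), so this change also shows up in solubility.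

The compounds shown leave open whether the higher intrinsic clearance goes with losing the ring nitrogen of piperidin-4-yl or with gaining an aromatic ring; a cyclohexyl group on the same saturated chain carbon would separate the two. Also open, going by these compounds, is how an amine on the phenyl would read in either assay.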